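This account rests on a few compounds, and the source may have more. Where it says the series, first, only, none or still open, it means among the compounds named here.

Among the compounds with values here, in a toxicity assay on L02 cells (Homo sapiens) for cytotoxicity, read by MTT assay, with a stated time of 72 h (a lower number here means a stronger inhibitor, a higher number a weaker inhibitor), compound 2 `O=C1c2c[n+]([O-])c3ccccc3c2C(=O)c2c1c1ccccc1n2CCCCN1CCCCC1` gives 610 nM, the higher of the two numbers so far, and compound 1 `CN1CCN(CCCCn2c3c(c4ccccc42)C(=O)c2c[n+]([O-])c4ccccc4c2C3=O)CC1` gives 80 nM. Compound 3 `CN1CCN(CCCn2c3c(c4ccccc42)C(=O)c2c[n+]([O-])c4ccccc4c2C3=O)CC1` differs from compound 2 as follows: 4-methylpiperazin-1-yl in place of (piperidin-1-yl)methyl on a saturated chain carbon, three bonds along the chain from an aromatic nitrogen. Within the data shown here, the one measured step that bears on this is a 7.6-fold higher number from compound 1 to compound 2 (0.88 log units; beyond the scatter), which exchanges the same two end groups in the opposite sense on an unchanged 4-carbon-named butyl chain. Among the measured compounds shown here, no measured pair shows the effect of the propyl chain alone. A step of similar size toward a lower number in this assay is therefore expected, a 5.5-fold lower number from compound 2 to compound 3 (0.74 log units; beyond the scatter). Compound 3 is estimated at 110 nM, with an expected range of 30 nM to 400 nM.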

Compound 3, half-maximal inhibitory concentration: 230 nM
The estimate for compound 3 lay 2.1-fold (0.32 log units) below the measured number; measured number inside the range.
By their numbers in this assay, from the lowest: compound 1; then compound 3; then compound 2.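

In this assay, the chain can now be judged on its own: with the 4-methylpiperazin-1-yl end group kept, going from butyl to propyl gives a 2.9-fold higher number from compound 1 to compound 3 (0.46 log units; beyond the scatter) on the shared core. The other step, a 2.7-fold lower number from compound 2 to compound 3 (0.42 log units; beyond the scatter), changes the end group and the chain together, so it cannot be credited to either change alone. Nothing measured here gives a reason for these steps.
Still open, as far as these compounds go, is how 3-(piperidin-1-yl)propyl would compare with compound 3, which would separate the end group from the chain on propyl. Also open, from the compounds shown here alone, is how a shorter ethyl chain, a longer pentyl chain or a morpholine end group would behave.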